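The source may hold more compounds than are shown below. What is called first, only, known or untested is meant among the compounds shown, and "the series" means these compounds.

Compound 1 `CC(=O)Nc1cc(-c2ccc(N(C)C(=O)c3c(F)cccc3Cl)c(N3CC4CC4C3)c2)n(C2CCC2)n1`: 0.5 ug/mL
Compound 2 `CC(=O)Nc1cc(-c2ccc(N(C)C(=O)c3c(F)cccc3Cl)c(N3CC4CC4C3)c2)n(C(C)C)n1`: 2.1 ug/mL
Compound 3 `CC(=O)Nc1cc(-c2ccc(N(C)C(=O)c3c(F)cccc3Cl)c(N3CC4CC4C3)c2)n(C(C)C2CC2)n1`: 0.5 ug/mL

In a physicochemical assay for solubility, measured as kinetic solubility (on this read-out higher numbers stand for higher solubility and lower numbers for lower solubility), compound 2 stands highest of the three, at 2.1 ug/mL. Compound 4 `CC(=O)Nc1cc(-c2ccc(N(C)C(=O)c3c(F)cccc3Cl)c(OCC(F)(F)F)c2)n(C(C)C)n1` differs from compound 2 by a group of 6 heavy atoms (2 carbon, 1 oxygen, 3 fluorine; no ring) in place of a group of 6 heavy atoms (5 carbon, 1 nitrogen; one three-membered non-aromatic ring of carbon only, one five-membered non-aromatic ring with 1 hetero atom), on an aromatic carbon, the entering group being 2,2,2-trifluoroethoxy. The measured steps all change the group on an aromatic nitrogen: a 4.2-fold higher number from compound 1 to compound 2 (0.62 log units; beyond the scatter), a 4.2-fold lower number from compound 2 to compound 3 (0.62 log units; beyond the scatter) and no change at the digits printed from compound 1 to compound 3 (within the scatter). None touches this aromatic carbon, so they give only a scale for steps in the series and no direction. No step beyond the scatter is therefore expected, though the uncertainty is wide. The expected step is a 1.2-fold higher number from compound 2 to compound 4 (0.08 log units; within the scatter). For compound 4 the estimated value is 2.5 ug/mL, with an expected range of 0.6 ug/mL to 10 ug/mL.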

Compound 4, solubility: 27 ug/mL
Beside the measured number, compound 4's estimate is 11-fold (1.03 log units) below it, and the stated range ends below it.
By their numbers in this assay, from the lowest: compounds 1 and 3 (each within the scatter of the next); then compound 2; then compound 4.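

In this assay, the aromatic carbon ortho to the ((2-chloro-6-fluorophenyl)carbonyl)(methyl)amino group is a position of strong effect: 2,2,2-trifluoroethoxy in place of the group bearing the three-membered and five-membered rings gives a 13-fold higher number from compound 2 to compound 4 (1.11 log units; beyond the scatter). This step is classed as large, whereas the steps on the aromatic nitrogen are modest or within the scatter. Nothing available explains the rise.

A single exchange does not separate loss of the leaving group from gain of 2,2,2-trifluoroethoxy, and methoxy or morpholine at this carbon would bear on that. On these data alone, whether the rise carries over to cyclobutyl or 1-cyclopropylethyl on the aromatic nitrogen remains open.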